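Swapping the halogen on the benzyl ether: expecting compound 4

The compounds below may be only part of what the source reports. "The series", "measured", "known", "first", "only" and "open" are said of these compounds alone.

Compound 1 `COc1cccc(C(=O)Oc2ccc3c(=O)c(-c4cc(OC)c(OC)cc4OC)coc3c2)c1` gives in a functional assay on HUVEC cells (Homo sapiens) for antiproliferative activity, read by MTT assay, with a stated time of 24 h (a higher number here means a weaker inhibitor, a lower number a stronger inhibitor), only a limit, > 10000 nM.
Compound 2 `COc1cc(OC)c(-c2coc3cc(OCc4ccc(Br)cc4)ccc3c2=O)cc1OC` gives in this assay only a limit, > 10000 nM.
Compound 3 `COc1cc(OC)c(-c2coc3cc(OCc4ccccc4C#N)ccc3c2=O)cc1OC` gives in this assay only a limit, > 10000 nM.

Compound 2 therefore stands at the limit of this assay, and so do the two other measured compounds (the limit of > 10000 nM in this assay, at which 3 of the 3 values shown sit). The steps a step that the two limits leave unreadable from compound 1 to compound 2, a step that the two limits leave unreadable from compound 1 to compound 3 and a step that the two limits leave unreadable from compound 2 to compound 3 stay unreadable because both ends of each sit at the limit (the limit of > 10000 nM in this assay, at which 3 of the 3 values shown sit).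

Compound 4 `COc1cc(OC)c(-c2coc3cc(OCc4ccccc4Cl)ccc3c2=O)cc1OC` differs from compound 2 in one place: 2-chlorophenyl in place of 4-bromophenyl on a saturated chain carbon bound to an oxygen on an aromatic ring. Within the data shown here, the step that the two limits leave unreadable from compound 2 to compound 3 touches the same place, but its size cannot be read, so no measured step gives a direction or a size to expect in this assay. Compound 4 is expected to remain at the limit, estimated at 15000 nM with a range from 5000 nM to 50000 nM. The expected step is a step that the limit leaves unreadable from compound 2 to compound 4.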

Compound 4, half-maximal inhibitory concentration: > 10000 nM
Compound 4 ended at the assay's limit; the forecaster's own chance of this, stated with the estimate: 80%; the middle value lies beyond the limit too.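

No new step can be read between compound 1, compound 2, compound 3 and compound 4, since each sits at the same limit: the limit of > 10000 nM in this assay, at which 4 of the 4 values shown sit.

The compounds shown leave open whether any group at this place would give a value inside the range of this assay.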